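Chain extension on the alkoxy-substituted core

This account rests on a few compounds, and the source may have more. Where it says the series, first, only, none or still open, it means among the compounds named here.

Measured compounds, with inhibition in an assay on microsomes from liver for inhibition of sterol O-acyltransferase 1 (Rattus norvegicus); a lower number here means a stronger inhibitor, a higher number a weaker inhibitor:
compound 1 `CCCCCCNc1cc(-c2ccccc2)c(-c2ccccc2)nn1`, 24000 nM
compound 2 `CCCCCCCNc1cc(-c2ccccc2)c(-c2ccccc2)nn1`, 55000 nM
compound 3 `CCCCCCCOc1cc(-c2ccccc2)c(-c2ccccc2)nn1`, 58000 nM

Compound 3 gives the highest of the three numbers in this assay; it lies within the scatter of compound 2 and a 2.4-fold higher number from compound 1 to compound 3 (0.38 log units; beyond the scatter). The unmeasured compound 4 `CCCCCCCCCOc1cc(-c2ccccc2)c(-c2ccccc2)nn1` differs from compound 3 by ethyl in place of hydrogen on a saturated chain carbon, seven bonds along the chain from an oxygen on an aromatic ring. Within the data shown here, the only measured step of the same kind, adding chain length on the amine series, reads a 2.3-fold higher number from compound 1 to compound 2 (0.36 log units; beyond the scatter). Exchange of the linking atom alone, a 1.1-fold higher number from compound 2 to compound 3 (0.02 log units; within the scatter), stays within the scatter. A modest rise is therefore expected for compound 4, estimated as a 1.6-fold higher number from compound 3 to compound 4 (0.19 log units; within the scatter), giving 90000 nM with a range from 35000 nM to 230000 nM.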

Compound 4, half-maximal inhibitory concentration: 180000 nM
The estimate for compound 4 lay 2.0-fold (0.30 log units) below the measured number; measured number inside the range.
By their numbers in this assay, from the lowest: compound 1; then compounds 2 and 3 (each within the scatter of the next); then compound 4.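

In this assay, ethyl in place of hydrogen on a saturated chain carbon, seven bonds along the chain from an oxygen on an aromatic ring, gives a 3.1-fold higher number from compound 3 to compound 4 (0.49 log units; beyond the scatter). Chain lengthening therefore raises the number with the oxygen link as well as with the nitrogen link, where the step reads a 2.3-fold higher number from compound 1 to compound 2 (0.36 log units; beyond the scatter). Nothing on hand bears on what lies behind this rise.

As far as these compounds go, whether a butoxy chain, or a chain bearing a carboxylic acid or an amine, would lower the number remains open.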